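The compounds below may be only part of what the source reports. "The series", "measured", "known", "first", "only" and "open" are said of these compounds alone.

Measured so far:
- compound 1 `O=C(/C=C/c1ccc([N+](=O)[O-])o1)c1ccc(C2CCCCC2)cc1` — in an ADME assay on Vero cells (Chlorocebus sabaeus) for cytotoxicity, read by resazurin assay, with a stated time of 72 h (on this read-out higher numbers stand for lower toxicity in this test and lower numbers for higher toxicity in this test), compound 1 gives > 100000 nM, a limit of the assay rather than a number.
- compound 2 `O=C(/C=C/c1ccc([N+](=O)[O-])s1)c1ccc(C2CCCCC2)cc1` — in this assay compound 2 is entered as "not determined" (no result reported), so no result is available.

Compound 2 therefore stands nowhere on the numbers shown: it has no value of its own. Among the measured compounds shown here, the only figure in this set is that of compound 1, and the one further value in the assay is a limit, as the limit of > 100000 nM in this assay, at which 1 of the 2 values shown sits, states. For the measured compounds named here, no step between measured compounds exists, so no measured shift can be drawn on.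

Compound 3 `CSc1ccc(C(=O)/C=C/c2ccc([N+](=O)[O-])s2)cc1` has not yet been tested in this assay. Compared with compound 2 it carries methylsulfanyl in place of cyclohexyl on an aromatic carbon, methylsulfanyl in place of cyclohexyl on an aromatic carbon. Going by the values given here, with no measured step at hand, no direction and no size of change beyond the scatter can be expected on evidence; the only anchor is that compound 1 sits at the limit. On that basis compound 3 is expected to give about 80000 nM in this assay, estimated within the range 20000 nM to 200000 nM, with a fair chance that only a limit is reported.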

Compound 3, half-maximal cytotoxic concentration: > 100000 nM
Compound 3: no number, only a limit; the forecaster's own chance of this, stated with the estimate: 50%; at least 1.2-fold (0.09 log units) between middle value and limit.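

In this assay compound 3 gives > 100000 nM, which is a limit and not a number. Compound 2 has no reported result, so no step can be read from compound 2 to compound 3. The compounds shown leave open whether methylsulfanyl in place of cyclohexyl changes the half-maximal cytotoxic concentration at all.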